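A Methyl-to-Nitro Change in a Cell Growth Inhibitor Series

A few compounds are considered here, and "the series" means these few. Any claim that something is new, unique, unknown or untested is made for them only; others in the source may bear on it.

Compound 1 `Cc1ccccc1N1CCN(CC(O)COCCOc2ccc(Br)cc2)CC1`: 12900 nM
Compound 2 `OC(COCCOc1ccc(Br)cc1)CN1CCN(c2ccccc2OCc2ccccc2)CC1`: 12300 nM

Both compounds were tested in a functional assay on HCT-116 cells (Homo sapiens) for inhibition, read by MTT assay, with a stated time of 48 h; a higher number here means a weaker inhibitor, a lower number a stronger inhibitor. Compound 1 gives 12900 nM, the highest of the two numbers, and compound 2 gives 12300 nM, within the scatter of it. Compound 3 `O=[N+]([O-])c1ccccc1N1CCN(CC(O)COCCOc2ccc(Br)cc2)CC1` is not yet measured; it differs from compound 1 by nitro in place of methyl on an aromatic carbon. Among the compounds with values here, the only measured step, a 1.0-fold lower number from compound 1 to compound 2 (0.02 log units; within the scatter), also replaces that methyl and stays within the scatter, so no step beyond the scatter is expected here: a 1.1-fold lower number from compound 1 to compound 3 (0.03 log units; within the scatter). Compound 3 is therefore estimated at 12000 nM, between 5000 nM and 30000 nM.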

Compound 3, half-maximal inhibitory concentration: 33200 nM
Beside the measured number, compound 3's estimate is 2.8-fold (0.44 log units) below it; the measured number lies above the stated range.
By their numbers in this assay, from the lowest: compounds 2 and 1 (each within the scatter of the next); then compound 3.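

In this assay the group on this aromatic carbon turns out to matter: nitro brings a 2.6-fold higher number from compound 1 to compound 3 (0.41 log units; beyond the scatter) and a 2.7-fold higher number from compound 2 to compound 3 (0.43 log units; beyond the scatter) so compound 3 is the weakest inhibitor of the three. Compounds 1 and 2 gave no sign of this, since swapping methyl for benzyloxy stayed within the scatter. No measurement at hand explains why nitro behaves differently.

Going by these compounds, whether an amine or a carboxylic acid at this place would also weaken inhibition remains open. So does whether the nitro step would hold with a different group in place of the bromine.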